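Hydroxamate and benzamide tails on a shared imidazoline core

The source may hold more compounds than are shown below. What is called first, only, known or untested is meant among the compounds shown, and "the series" means these compounds.

Measured compounds:
compound 1 `CCOc1cc(C(C)(C)C)ccc1C1=NC(c2ccc(Cl)cc2)C(c2ccc(Cl)cc2)N1C(=O)N1CCN(CCCCCCCC(=O)NO)CC1`: a functional assay on MCF7 cells (Homo sapiens) for antiproliferative activity, read by CCK-8 assay, with a stated time of 72 h (a lower number here means a stronger inhibitor, a higher number a weaker inhibitor), 4830 nM
compound 2 `CCOc1cc(C(C)(C)C)ccc1C1=NC(c2ccc(Cl)cc2)C(c2ccc(Cl)cc2)N1C(=O)NCCCCCCC(=O)Nc1ccccc1N`: this assay > 100000 nM, which is a limit of the assay and not a number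
compound 3 `CCOc1cc(C(C)(C)C)ccc1C1=NC(c2ccc(Cl)cc2)C(c2ccc(Cl)cc2)N1C(=O)NCCCCCCCC(=O)Nc1ccccc1N`: this assay 20300 nM

Compound 1 gives the lowest of the two numbers, with compound 3 next and beyond the scatter. Among the compounds with values here, the only single-point step is an at least 4.9-fold lower number from compound 2 to compound 3 (0.69 log units; beyond the scatter), which concerns the benzamide tail and not the hydroxamate. Compound 4 `CCOc1cc(C(C)(C)C)ccc1C1=NC(c2ccc(Cl)cc2)C(c2ccc(Cl)cc2)N1C(=O)N1CCN(c2ncc(C(=O)NO)cn2)CC1` differs from compound 1 by 5-(hydroxycarbamoyl)pyrimidin-2-yl in place of 7-(hydroxycarbamoyl)heptyl on an amine nitrogen in a ring. Within the data shown here, no measured step touches the amine nitrogen in a ring or the hydroxycarbamoyl group, so the step is read from compound 1 alone and is expected to be small, at most near the scatter, as a 1.6-fold lower number from compound 1 to compound 4 (0.21 log units; within the scatter). Compound 4 is estimated at 3000 nM, between 700 nM and 15000 nM.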

Compound 4, half-maximal inhibitory concentration: 3460 nM
Compound 4: the middle estimate sits 1.2-fold (0.06 log units) below what was measured, and the stated range covers the measured number.
By their numbers in this assay, from the lowest: compounds 4 and 1 (each within the scatter of the next); then compound 3. At a limit, above all of these: compound 2.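

Replacing 7-(hydroxycarbamoyl)heptyl with 5-(hydroxycarbamoyl)pyrimidin-2-yl on the amine nitrogen in a ring gives, in this assay, a 1.4-fold lower number from compound 1 to compound 4 (0.14 log units; within the scatter). At this position, a tail with no ring and a tail with a six-membered aromatic ring, each carrying the hydroxycarbamoyl group, are therefore not separated by this read-out. No measurement shown bears on the reason for this step.

Going by these compounds, whether the hydroxycarbamoyl group is needed on these tails remains open. Also open, on these data alone, is how a carboxylic acid in its place, or a longer chain, would read.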